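Prenyl benzamide series: amine side chain, compound 3 to 4

A few compounds are considered here, and "the series" means these few. Any claim that something is new, unique, unknown or untested is made for them only; others in the source may bear on it.

Measured in a functional assay on SK-BR-3 cells (Homo sapiens) for antiproliferative activity; a higher number here means a weaker inhibitor, a lower number a stronger inhibitor:
- compound 1 `CC(C)=CCc1cc(C(=O)Nc2cc3ccc(OCC4CCCN(C)C4)c(C)c3oc2=O)ccc1O`: 1300 nM
- compound 2 `CC(C)=CCc1cc(C(=O)Nc2cc3ccc(OCCCNC(C)C)c(C)c3oc2=O)ccc1O`: 750 nM
- compound 3 `CC(C)=CCc1cc(C(=O)Nc2cc3ccc(OCCCNC(C)(C)C)c(C)c3oc2=O)ccc1O`: 660 nM

Compound 3 is not separated from the other two compounds: the data show a 1.1-fold lower number from compound 2 to compound 3 (0.06 log units; within the scatter) and a 2.0-fold lower number from compound 1 to compound 3 (0.29 log units; within the scatter). The next change leads to compound 4 `CC(C)=CCc1cc(C(=O)Nc2cc3ccc(OCCCNCCO)c(C)c3oc2=O)ccc1O`: 2-hydroxyethyl in place of tert-butyl on an amine nitrogen.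

The closest measured precedent is a 1.1-fold lower number from compound 2 to compound 3 (0.06 log units; within the scatter), which also alters the group on that amine nitrogen. The broader side-chain change gave a 1.7-fold lower number from compound 1 to compound 2 (0.24 log units; within the scatter). Among the measured compounds shown here, no measured compound carries 2-hydroxyethyl, so the data contain no direct step for this group. With every measured step inside the scatter, no shift beyond the scatter is expected in this assay, and these steps indicate no firm direction. The expected step is a 1.2-fold higher number from compound 3 to compound 4 (0.08 log units; within the scatter). For compound 4 the estimated value is 800 nM, with an expected range of 300 nM to 2200 nM.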

Compound 4, half-maximal inhibitory concentration: 610 nM
The estimate for compound 4 lay 1.3-fold (0.12 log units) above the measured number; measured number inside the range.
By their numbers in this assay, from the lowest: compounds 4, 3, 2 and 1 (each within the scatter of the next, the first and the last beyond it).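

In this assay, 2-hydroxyethyl in place of tert-butyl on the amine nitrogen gives a 1.1-fold lower number from compound 3 to compound 4 (0.03 log units; within the scatter), and in place of isopropyl it gives a 1.2-fold lower number from compound 2 to compound 4 (0.09 log units; within the scatter); this nitrogen therefore accepts a group with a hydrogen-bond donor and acceptor as readily as the two branched alkyl groups, with no separation in the number. The change from 1-methylpiperidin-3-yl to 2-((2-hydroxyethyl)amino)ethyl gives a 2.1-fold lower number from compound 1 to compound 4 (0.33 log units; beyond the scatter), the only step among these compounds printed as beyond the scatter, and it is modest. No evidence at hand accounts for these numbers.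

Open, from the compounds shown here alone, is whether a 3-hydroxypropyl or 2-methoxyethyl group on this nitrogen would stay within the scatter of compound 4. A carboxylic acid on the chain, or a tertiary amine carrying methyl alongside 2-hydroxyethyl, is likewise unresolved.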